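The compounds below may be only part of what the source reports. "The series", "measured", "known", "first", "only" and "open" are said of these compounds alone.

The set consists of four close relatives of one shared core, assessed in a functional assay on MT4 cells (Homo sapiens), read by MTT assay; on this read-out higher numbers stand for lower toxicity in this test and lower numbers for higher toxicity in this test. Compound 1 `C#C[C@]1(CO)O[C@@H](n2cc(Br)c(=O)[nH]c2=O)C[C@@H]1O` carries a bromo group on its aromatic ring. In this assay compound 1 gives > 100000 nM, which is a limit of the assay and not a number. Compound 2 `C#C[C@]1(CO)O[C@@H](n2cc(I)c(=O)[nH]c2=O)C[C@@H]1O` differs from compound 1 by iodo in place of bromo on an aromatic carbon. In this assay compound 2 gives > 260000 nM, again a limit rather than a measured number. The step in this assay from compound 1 to compound 2 is therefore a step that the two limits leave unreadable from compound 1 to compound 2, since both values rest on limits, the limit of > 100000 nM in this assay, at which 2 of the 3 values shown sit, and (the limit of > 260000 nM in this assay, at which 1 of the 3 values shown sits).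

Compound 3 `C#C[C@]1(CO)O[C@@H](n2cc(Br)c(N)nc2=O)C[C@@H]1O` has a different core; how the core of compound 3 differs from that of compound 1 is not broken down here. In this assay compound 3 gives > 100000 nM, which is a limit of the assay.

Compound 4 `C#C[C@]1(CO)O[C@@H](n2cc(I)c(N)nc2=O)C[C@@H]1O` is not yet measured and differs from compound 3 by iodo in place of bromo on an aromatic carbon. This is the same kind of change as that from compound 1 to compound 2, though not the same: in compound 4 the bromo-to-iodo exchange sits ortho to an amino group (1 heavy atom), whereas in compound 2 it sits ortho to a group of 1 heavy atom.

Because compound 3 already sits at the limit (the limit of > 100000 nM in this assay, at which 2 of the 3 values shown sit), the step from compound 3 to compound 4 in this assay is expected to be a step that the limit leaves unreadable from compound 3 to compound 4, with no numbered value likely. Compound 4 is estimated to give 200000 nM in this assay, within 80000 nM to 600000 nM.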

Compound 4, half-maximal cytotoxic concentration: > 100000 nM
Compound 4: no number, only a limit; the forecaster's own chance of this, stated with the estimate: 85%; the middle value does not contradict the limit.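

In this assay, compound 4 gives > 100000 nM, which is a limit of the assay and not a number. Compound 3 and compound 4 both rest on a limit, so no size can be read for the step between them: the limit of > 100000 nM in this assay, at which 3 of the 4 values shown sit.

The compounds shown leave open at what concentration any of the four would become toxic in this test, and whether exchanging bromo for iodo changes that concentration at all.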